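A few compounds are considered here, and "the series" means these few. Any claim that something is new, unique, unknown or untested is made for them only; others in the source may bear on it.

Measured compounds:
- compound 1, `Nc1ccc(S(=O)(=O)Nc2ccnc3cc(C(F)(F)F)ccc23)cc1`, in a functional assay on HepG2 cells (Homo sapiens) for antiproliferative activity, read by sulforhodamine B assay, with a stated time of 48 h; on this read-out higher numbers stand for weaker inhibition and lower numbers for stronger inhibition: 93100 nM
- compound 2, `Cc1cc(NS(=O)(=O)c2ccc(N/C(S)=N\c3ccnc4cc(C(F)(F)F)ccc34)cc2)on1`, in this assay: 28500 nM

Of these two numbers, compound 2 holds the lower one, and its gap to compound 1 lies beyond the usual scatter. Compound 3, `Cc1cc(C)nc(NS(=O)(=O)c2ccc(N/C(S)=N\c3ccnc4cc(C(F)(F)F)ccc34)cc2)n1`, differs from compound 2 in one place: 4,6-dimethylpyrimidin-2-yl in place of 3-methyl-1,2-oxazol-5-yl on a sulfonamide nitrogen. Going by the values given here, no pair of measured compounds isolates this change, so the expectation rests on compound 2 alone, and the step from compound 2 to compound 3 is estimated at a 1.1-fold lower number from compound 2 to compound 3 (0.06 log units; within the scatter), within the scatter. Compound 3 is therefore expected to give about 25000 nM, with a range from 8000 nM to 80000 nM.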

Compound 3, half-maximal inhibitory concentration: 72200 nM
The estimate for compound 3 lay 2.9-fold (0.46 log units) below the measured number; low and high end bracket the measured number.
By their numbers in this assay, from the lowest: compound 2; then compounds 3 and 1 (each within the scatter of the next).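

Going by these compounds alone, compound 2 and compound 3 differ only in the group on the sulfonamide nitrogen, and they give the first clean reading of this position: in this assay, placing 4,6-dimethylpyrimidin-2-yl there in place of 3-methyl-1,2-oxazol-5-yl gives a 2.5-fold higher number from compound 2 to compound 3 (0.40 log units; beyond the scatter), a modest weakening of inhibition. The two groups have equal counts of hydrogen-bond donors and acceptors, so those counts do not account for the difference. No measurement shown explains this step.

On these data alone, whether the ring itself or its two methyl groups matter remains open. So does how an unsubstituted pyrimidin-2-yl or a plain phenyl ring would read at this nitrogen.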